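Sulfonate series: iodo for isopropyl beside the urea

The source may hold more compounds than are shown below. What is called first, only, known or untested is meant among the compounds shown, and "the series" means these compounds.

Compound 1 `CC(=O)Nc1ccc(S(=O)(=O)Oc2ccccc2C(C)C)cc1` is the starting point; in a functional assay on HT-1080 cells (Homo sapiens) for antiproliferative activity, read by sulforhodamine B assay, with a stated time of 48 h (on this read-out lower numbers stand for stronger inhibition and higher numbers for weaker inhibition), compound 1 gives 12000 nM. Compound 2 `CC(=O)Nc1ccc(S(=O)(=O)Oc2ccccc2I)cc1` carries iodo in place of isopropyl on an aromatic carbon and in this assay compound 2 gives 17000 nM, so that a 1.4-fold higher number from compound 1 to compound 2 (0.15 log units; within the scatter). Compound 3 `CCCNC(=O)Nc1ccc(S(=O)(=O)Oc2ccccc2C(C)C)cc1` keeps the isopropyl of compound 1 but differs at the carbonyl carbon by propylamino in place of methyl on a carbonyl carbon; in this assay compound 3 gives 680 nM, and an 18-fold lower number from compound 1 to compound 3 (1.25 log units; beyond the scatter). Compound 3 thus stands lowest of the three measured numbers, with both other compounds beyond the scatter from it.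

Compound 4 `CCCNC(=O)Nc1ccc(S(=O)(=O)Oc2ccccc2I)cc1` has not been measured in this assay. It differs from compound 3 by iodo in place of isopropyl on an aromatic carbon, the same change, at the same kind of place, that separates compound 1 from compound 2; the two cores, that of compound 3 and that of compound 1, differ by propylamino in place of methyl on a carbonyl carbon. The step is expected to be small, about a 1.4-fold higher number from compound 3 to compound 4 (0.15 log units; within the scatter), because a 1.4-fold higher number from compound 1 to compound 2 (0.15 log units; within the scatter) stayed within the scatter on the acetamide core. Whether the urea core of compound 3 behaves the same way is not shown by any other pair here. Compound 4 is therefore estimated at 950 nM in this assay, most likely between 400 nM and 2500 nM.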

Compound 4, half-maximal inhibitory concentration: 700 nM
Estimate against measurement, compound 4: 1.4-fold (0.13 log units) above, and the stated range covers the measured number.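

In this assay, iodo in place of isopropyl on the core of compound 3 gives a 1.0-fold higher number from compound 3 to compound 4 (0.01 log units; within the scatter), and this step agrees with the one seen earlier on the core of compound 1: the same change on two cores in this assay, a 1.4-fold higher number (0.15 log units; within the scatter) from compound 1 to compound 2 and a 1.0-fold higher number (0.01 log units; within the scatter) from compound 3 to compound 4, 1.4-fold (0.14 log units) apart, within the scatter of two such steps. Propylamino in place of methyl on a carbonyl carbon gives a 24-fold lower number from compound 2 to compound 4 (1.39 log units; beyond the scatter) with iodo on the aromatic carbon, and this large step agrees with the one seen with isopropyl there: the same change on two cores in this assay, an 18-fold lower number (1.25 log units; beyond the scatter) from compound 1 to compound 3 and a 24-fold lower number (1.39 log units; beyond the scatter) from compound 2 to compound 4, 1.4-fold (0.14 log units) apart, within the scatter of two such steps. Across these four compounds the two changes therefore carry from one core to the other without visible interaction, but this rests on a single pair of cores and a single pair of groups at each place, so it shows no general rule for the series and gives no reason for either step.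

Still open, from the compounds shown here alone, is whether the exchange stays this small with other groups on that aromatic carbon, such as a chloro, methoxy or tert-butyl group, and whether the gain on the carbonyl carbon follows the chain, as with butylamino or a longer chain, or survives a cyclohexylamino group. A carboxylic acid or a basic amine at the end of that chain is equally untested by the compounds shown here.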